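Replacing the Methoxy Group of Compound 3 with Ethyl

This account rests on a few compounds, and the source may have more. Where it says the series, first, only, none or still open, it means among the compounds named here.

Compound 1 `CCCc1nc(C)c2cnnc(O)n12` gives 56800 nM in a functional assay for inhibition, with Homo sapiens as the target (on this read-out lower numbers stand for stronger inhibition and higher numbers for weaker inhibition), a weak result. Compound 2 `CCCc1ncc2c(C)nnc(O)n12` gives only a limit of this assay, > 48000 nM. Compound 3 `COCc1ncc2cnnc(O)n12` likewise gives only a limit of this assay, > 48000 nM. Compound 3 therefore stands at the weak end of what has been measured, and the picture as a whole is set by the limit of > 48000 nM in this assay, at which 2 of the 3 values shown sit.

Compound 4 `CCCc1ncc2cnnc(O)n12` has not yet been measured. It differs from compound 3 by ethyl in place of methoxy on a saturated chain carbon bound to an aromatic carbon. Among the compounds with values here, no measured pair shows this change on its own, so its effect cannot be read from the data; the only guidance is that compound 1, which also carries a propyl chain, gives 56800 nM in this assay. The step from compound 3 to compound 4 is expected to be a step that the limit leaves unreadable from compound 3 to compound 4, that is, none beyond the scatter. Compound 4 is accordingly estimated at 60000 nM, within a range from 30000 nM to 150000 nM, with a substantial chance that this assay again reports only a limit.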

Compound 4, half-maximal inhibitory concentration: > 48000 nM
Compound 4: no number, only a limit; the forecaster's own chance of this, stated with the estimate: 60%; the middle value does not contradict the limit.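

Compound 4 also gives only a limit in this assay, > 48000 nM. No step to it from compound 1, compound 2 or compound 3 can be read, because the values rest on the assay's limit: the limit of > 48000 nM in this assay, at which 3 of the 4 values shown sit.

The compounds shown leave open how far ethyl in place of methoxy, or hydrogen in place of methyl, shifts inhibition.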